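Tolerance of a Shared Core Across Three Aryl Variations

The source may report more compounds than this note shows. Statements on the series, on what has been measured and on what is new or still open speak of the compounds shown alone.

The series rests on the core shared by compound 1 `COc1ccc([C@H]2CC(=O)N(c3cccc(N(C)C)c3)C2)cc1OC1CCCC1`, compound 2 `COc1ccc([C@H]2CC(=O)N(c3ccc(C)c(N)c3)C2)cc1OC1CCCC1`, compound 3 `COc1ccc([C@H]2CC(=O)N(c3ccc(C#N)cc3)C2)cc1OC1CCCC1` and the still unmeasured compound 4 `COc1ccc([C@H]2CC(=O)N(c3ccccc3C(F)(F)F)C2)cc1OC1CCCC1`. In a functional assay on HEK293 cells (Homo sapiens) for cytotoxicity (a higher number here means that more compound is tolerated, a lower number that less compound is tolerated), compound 1 reaches only a limit of the assay, > 10000 nM. For compound 2 the value is likewise a limit, > 10000 nM. For compound 3 it is also a limit, > 10000 nM. Compound 1 therefore stands at the tolerated edge of what this assay can report, and its two neighbours stand there with it, as the limit of > 10000 nM in this assay, at which 3 of the 3 values shown sit, sums up.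

The move to compound 4 is 2-(trifluoromethyl)phenyl in place of 3-(dimethylamino)phenyl on an amide-type nitrogen in a ring. Going by the values given here, three measured steps bear on it: a step that the two limits leave unreadable from compound 1 to compound 2, a step that the two limits leave unreadable from compound 1 to compound 3 and a step that the two limits leave unreadable from compound 2 to compound 3. Among the compounds with values here, none of them yields a readable size, so they offer no direction for the new change; they show only that three different groups on the amide-type nitrogen in a ring all left tolerance at the limit. The writer therefore expects the step that the limit leaves unreadable from compound 1 to compound 4 to stay within the scatter, most likely ending in another limit. Compound 4 is estimated at 15000 nM, with a range from 8000 nM to 40000 nM.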

Compound 4, half-maximal cytotoxic concentration: > 10000 nM
Compound 4: only a limit was reported (the forecaster's own chance of this, stated with the estimate: 85%); the middle value does not contradict the limit.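

In this assay compound 4 gives > 10000 nM, which is a limit of the assay. Its steps from compound 1, compound 2 and compound 3 therefore cannot be read, and the four compounds stay together: the limit of > 10000 nM in this assay, at which 4 of the 4 values shown sit. The compounds shown leave open at what concentration any of them becomes cytotoxic, and whether the group on the amide-type nitrogen in a ring influences tolerance at all.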